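The source may report more compounds than this note shows. Statements on the series, on what has been measured and on what is new or still open speak of the compounds shown alone.

Working notes on the series. In a functional assay on MES-SA/Dx5 cells (Homo sapiens) for inhibition, with a stated time of 72 h (a higher number here means a weaker inhibitor, a lower number a stronger inhibitor), compound 1 (`CC(C)OCc1cc(CN2CCCCC2)c(O)c2ncccc12`) gives 479 nM and compound 2 (`COCc1cc(CN2CCC(C)CC2)c(O)c2ncccc12`) gives 575 nM, so the two lie within the scatter of each other. Compound 3 (`CC1CCN(Cc2cc(COC(C)C)c3cccnc3c2O)CC1`) differs from compound 2 by isopropyl in place of methyl on an oxygen on a saturated carbon. Among the measured compounds shown here, no measured pair isolates this change. Compound 1 carries the same isopropyl and gives 479 nM, so no shift beyond the scatter is expected in this assay. The expected step is a 1.2-fold lower number from compound 2 to compound 3 (0.08 log units; within the scatter). Compound 3 is estimated at 480 nM, with an expected range of 220 nM to 1050 nM.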

Compound 3, half-maximal inhibitory concentration: 355 nM
Beside the measured number, compound 3's estimate is 1.4-fold (0.13 log units) above it; the measured number falls inside the stated range.
By their numbers in this assay, from the lowest: compounds 3, 1 and 2 (each within the scatter of the next).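

Isopropyl in place of methyl on an oxygen on a saturated carbon now has a directly measured pair in this assay (a 1.6-fold lower number from compound 2 to compound 3 (0.21 log units; within the scatter)), so the comparison no longer rests on compound 1 alone. Methyl in place of hydrogen on a saturated ring carbon can also be read for the first time, with isopropyl held constant (a 1.3-fold lower number from compound 1 to compound 3 (0.13 log units; within the scatter)). Neither change moves the number beyond the scatter. Only methyl and isopropyl are shown on this oxygen, so the outcome with a longer chain such as butyl, or with a phenyl ring, remains open. No measurement on hand bears on these numbers.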